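Lengthening the ester chain from compound 3 to compound 4

The source may hold more compounds than are shown below. What is called first, only, known or untested is meant among the compounds shown, and "the series" means these compounds.

Compound 3 `CCOC(=O)c1ccc(-c2csc(NC(=O)C(=O)OC)n2)cc1` has no numerical result in a functional assay on the whole organism with Rattus norvegicus as the target; a lower number here means that less compound is needed, a higher number that more compound is needed for the effect. Compound 3 gives > 10 mg/kg, which is a limit. Compound 1 `CCCC(=O)Nc1ccc(-c2csc(NC(=O)C(=O)OCC)n2)cc1` also reaches only a limit, > 10 mg/kg. Compound 2 `CCOC(=O)C(=O)Nc1ccc(-c2csc(NC(=O)C(=O)OCC)n2)cc1` likewise gives only a limit, > 30 mg/kg.

Compound 4 `CCCCOC(=O)C(=O)Nc1nc(-c2ccc(C(=O)OCC)cc2)cs1` differs from compound 3 by propyl in place of hydrogen on a saturated chain carbon bound to an oxygen next to a carbonyl group, which turns methoxycarbonyl into butoxycarbonyl (propyl in place of hydrogen on a saturated chain carbon bound to an oxygen next to a carbonyl group). Among the measured compounds shown here, the only measured step, a step that the two limits leave unreadable from compound 1 to compound 2, is a different change, ethoxycarbonyl in place of propyl on a carbonyl carbon. It gives neither a size nor a direction for this one. With so little to go on, no clear shift in this assay is expected, and a further limit is the likeliest result. The expected step is a step that the limit leaves unreadable from compound 3 to compound 4, and this estimate is only tentative. For compound 4 the estimated value is 20 mg/kg, with an expected range from 6 mg/kg to 60 mg/kg.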

Compound 4, dose for half-maximal effect: > 10 mg/kg
Compound 4 was reported as a limit; the forecaster's own chance of this, stated with the estimate: 70%; the middle value does not contradict the limit.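

Compound 3 and compound 4 are both reported only as limits in this assay, so no step can be read between them. The compounds shown leave open whether butoxycarbonyl in place of methoxycarbonyl changes the dose needed for the effect at all.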